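Cytotoxicity notes: from 2,4-dichlorophenyl to phenyl

The source may report more compounds than this note shows. Statements on the series, on what has been measured and on what is new or still open speak of the compounds shown alone.

In a functional assay on HepG2 cells (Homo sapiens) for cytotoxicity, read by MTT assay, with a stated time of 72 h (a higher number here means a weaker inhibitor, a lower number a stronger inhibitor), compound 1 `CNC(=O)c1cc(Oc2ccc(C3=NNC(c4ccc(Cl)cc4Cl)C3)cc2)ccn1` has the entry "not determined" (no result reported), so it stands at no single number. The nearest measured compound is compound 2 `CNC(=O)c1cc(Oc2ccc(C3=NNC(c4ccc(F)cc4Cl)C3)cc2)ccn1`, at 11500 nM. The step under study leads to compound 3 `CNC(=O)c1cc(Oc2ccc(C3=NNC(c4ccccc4)C3)cc2)ccn1`. The change is phenyl in place of 2,4-dichlorophenyl on a saturated ring carbon. For the measured compounds named here, no step between measured compounds exists in this assay, so the expected change is none beyond the scatter, in neither direction, and the only anchor is compound 2 at 11500 nM. For compound 3 the expected value is 14000 nM, with an estimated range of 5500 nM to 36000 nM.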

Compound 3, half-maximal inhibitory concentration: 1500 nM
The estimate for compound 3 lay 9.3-fold (0.97 log units) above the measured number; the measured number lies below the stated range.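

In this assay the aryl group on this saturated ring carbon proves to matter: taking away both halogens gives a 7.7-fold lower number from compound 2 to compound 3 (0.88 log units; beyond the scatter) and places plain phenyl clearly under 2-chloro-4-fluorophenyl on the shared core. The series thus has its first readable step at this position, and it runs toward the unsubstituted ring. No measurement at hand offers an explanation for this shift. The compounds shown leave open which halogen accounts for the step, and whether a phenyl carrying an amine or a carboxylic acid would lie in the same direction.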